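Hydrazone variations on a weak monoamine oxidase B scaffold

The compounds below may be only part of what the source reports. "The series", "measured", "known", "first", "only" and "open" are said of these compounds alone.

Three compounds share a core built on a benzyl-bearing bicyclic aromatic ring that carries a hydrazone arm. Compound 1 `COc1ccccc1/C=N/Nc1nc2ccccc2nc1Cc1ccccc1` carries a methoxy-bearing aromatic ring on that arm, and in an assay on isolated protein for inhibition of Amine oxidase [flavin-containing] B (Homo sapiens), read by spectrophotometry (on this read-out lower numbers stand for stronger inhibition and higher numbers for weaker inhibition), compound 1 gives 790000 nM. Compound 2 `C/C(=N\Nc1nc2ccccc2nc1Cc1ccccc1)c1ccccc1` instead bears a methyl-substituted hydrazone with a plain aromatic ring, and in this assay compound 2 gives 980000 nM. Compound 2 shows the highest of the two numbers measured, but its gap to compound 1 lies within the usual scatter, so the two cannot be told apart on these data.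

Compound 3 `Brc1cccc(/C=N/Nc2nc3ccccc3nc2Cc2ccccc2)c1` has not yet been measured. Relative to compound 2 the change is a group of 9 heavy atoms (7 carbon, 1 nitrogen, 1 bromine; one six-membered aromatic ring of carbon only) in place of a group of 9 heavy atoms (8 carbon, 1 nitrogen; one six-membered aromatic ring of carbon only), on a nitrogen on an aromatic ring. Among the measured compounds shown here, no measured pair here isolates a change of this kind, so nothing in the data says which way such a swap moves the number. Both measured compounds sit at very weak inhibition, and compound 3 is expected to stay in that region. The step of a 1.4-fold lower number from compound 2 to compound 3 (0.15 log units; within the scatter) is expected to be small and within the scatter. Compound 3 is estimated at 700000 nM, with a range from 200000 nM to 2500000 nM.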

Compound 3, half-maximal inhibitory concentration: 48000 nM
Compound 3: the middle estimate sits 15-fold (1.16 log units) above what was measured; the whole stated range lies above it.
By their numbers in this assay, from the lowest: compound 3; then compounds 1 and 2 (each within the scatter of the next).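

The hydrazone arm looked unresponsive while only compound 1 and compound 2 were available, but it can move the number strongly: the swap at this nitrogen-linked position gives a 20-fold lower number from compound 2 to compound 3 (1.31 log units; beyond the scatter), so very weak inhibition is not fixed for this shared core. Compound 2 differs from compound 3 in two features within that swap, the methyl on the hydrazone carbon and the bromine, but compound 1 lacks that methyl as compound 3 does, and 3-bromophenyl in place of 2-methoxyphenyl on a carbon with a double bond to nitrogen still gives a 16-fold lower number from compound 1 to compound 3 (1.22 log units; beyond the scatter), so the change on the aromatic ring alone is enough for a large step. Nothing measured here explains why the number falls.

The step from compound 1 changes both the substituent and its place on the ring, so the compounds shown cannot separate the effect of the bromine itself from that of where it sits. Also open, going by these compounds, are whether a chlorine or an amine in the bromine's place would keep the stronger inhibition, and how the methyl of compound 2 would behave alongside the bromine.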